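Exchanging 4-methoxyphenyl for 4-bromophenyl in compound 2

This account rests on a few compounds, and the source may have more. Where it says the series, first, only, none or still open, it means among the compounds named here.

Measured in a functional assay on A549 cells (Homo sapiens) for antiproliferative activity, read by MTT assay, with a stated time of 24 h; a higher number here means a weaker inhibitor, a lower number a stronger inhibitor:
- compound 1 `COc1ccc(S(=O)(=O)n2c(-c3cn(-c4ccccc4)nc3-c3ccc(F)cc3)nc3ccccc32)cc1`: 350 nM
- compound 2 `COc1ccc(S(=O)(=O)n2c(-c3cn(-c4ccccc4)nc3-c3ccc(C(F)(F)F)cc3)nc3ccccc32)cc1`: 170 nM

Of these two compounds, compound 2 has the lower number, at 170 nM, so it is the stronger inhibitor. The next compound is compound 3 `O=S(=O)(c1ccc(Br)cc1)n1c(-c2cn(-c3ccccc3)nc2-c2ccc(C(F)(F)F)cc2)nc2ccccc21`, which has bromo in place of methoxy on an aromatic carbon, para to a large group: bromo in place of methoxy on an aromatic carbon. Going by the values given here, only one measured step is available, a 2.1-fold lower number from compound 1 to compound 2 (0.31 log units; beyond the scatter). That modest step exchanged fluoro for trifluoromethyl and left the methoxy untouched, so it offers only a rough scale. Among the compounds with values here, no measured step tests the present change. A small step in this assay is therefore expected, perhaps none beyond the scatter, and the direction is uncertain, with a slight lean towards a higher number. The expected change is a 1.2-fold higher number from compound 2 to compound 3 (0.07 log units; within the scatter). For compound 3, the estimated value is 200 nM, within an expected range of 70 nM to 550 nM.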

Compound 3, half-maximal inhibitory concentration: 1690 nM
Compound 3: the middle estimate sits 8.5-fold (0.93 log units) below what was measured, outside the stated range (above it).
By their numbers in this assay, from the lowest: compound 2; then compound 1; then compound 3.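

In this assay, the group on the aromatic carbon para to a large group proves to matter: exchanging 4-methoxyphenyl for 4-bromophenyl gives a 9.9-fold higher number from compound 2 to compound 3 (1.00 log units; beyond the scatter). Going by these compounds alone, the earlier compounds kept the methoxy fixed, and their only step, a 2.1-fold lower number from compound 1 to compound 2 (0.31 log units; beyond the scatter), is smaller, so this sulfonyl-bound ring is the more sensitive of the two places varied so far. No measurement shown here accounts for the weaker result with bromo.

With only methoxy and bromo shown at this position, it remains open whether the result reflects the departure of methoxy or the arrival of bromo, and a hydroxyl, an amine or a plain hydrogen there could help separate the two. On these data alone, it is also open whether the exchange would have a similar effect with fluoro in place of trifluoromethyl on the other ring.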